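Enantiomer swap in the alkyne-amide mGlu5 modulator pair

The source may report more compounds than this note shows. Statements on the series, on what has been measured and on what is new or still open speak of the compounds shown alone.

Measured so far:
compound 1 `C[C@@H](NC(=O)c1ccc(C#Cc2cc(F)cc(F)c2)cn1)C(C)(C)O` 61.6%
compound 2 `C[C@@H](NC(=O)c1ccc(C#Cc2cccc(F)c2)cn1)C(C)(C)C` 66%

In a functional assay on HEK293 cells for positive allosteric modulation of metabotropic glutamate receptor 5 (Rattus norvegicus), read by fluorescence and calcium flux (on this read-out lower numbers stand for smaller maximal responses and higher numbers for larger maximal responses), compound 2 gives 66%, the higher of the two numbers shown, and compound 1 gives 61.6%, a result within the scatter of that for compound 2, so no order can be read between them. Among the measured compounds shown here, both compounds were run in this assay only, and no step between two measured compounds that differ in one place is available.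

Compound 3 `C[C@H](NC(=O)c1ccc(C#Cc2cccc(F)c2)cn1)C(C)(C)C` is not yet measured. Its relation to compound 2 is the two compounds have the same atoms and bonds and differ only in configuration as drawn: 1 of 1 stereo elements differ; a stereocentre at a saturated chain carbon is drawn R in compound 2 and S in compound 3. Nothing in the measured pair shows what inverting this centre does, so no direction can be taken from the data. With that unknown, compound 3 is expected at 52%, with a range from 25% to 78%, which means a step of a number 14 percentage points lower from compound 2 to compound 3 (beyond the scatter) that is estimated downward but with a range reaching the scatter in either direction.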

Compound 3, largest response reached (reported as efficacy), in percent of the reference or control that the assay uses: 70.8%
Compound 3: middle estimate off by 18.8 percentage points, on the low side, and the stated range covers the measured number.
By their numbers in this assay, from the lowest: compounds 1, 2 and 3 (each within the scatter of the next).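

In this assay, among the compounds shown here, inverting the stereocentre at the saturated chain carbon gives a number 4.8 percentage points higher from compound 2 to compound 3 (within the scatter), the first single-change step. The maximal response therefore does not separate the R and S forms of this centre, at least with the chain and the fluorinated aryl alkyne shared by this pair. The comparison is a clean test of this one centre, and the reading rests on a single structural fact: the fact that compounds 2 and 3 differ only in the configuration as drawn.

This pair says nothing about whether the same holds for the hydroxyl-bearing chain of compound 1, or for potency, since only maximal response is shown here. From the compounds shown here alone, how a primary amine or a carboxylic acid on this chain would behave in either configuration also remains open.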